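Three Measured Compounds and One Still to Be Tested

The compounds below may be only part of what the source reports. "The series", "measured", "known", "first", "only" and "open" are said of these compounds alone.

Compound 1 `Cc1ccc(Oc2cccc(CN3CCC(n4cc(C)c(=O)[nH]c4=O)CC3)c2)cc1`: > 64000 nM, a limit of the assay.
Compound 2 `Cc1cn(C2CCN(Cc3cccc(Oc4cc(F)cc(F)c4)c3)CC2)c(=O)[nH]c1=O`: > 64000 nM, also a limit.
Compound 3 `Cc1cn(C2CCN(Cc3cccc(Oc4ccc(Cl)cc4)c3)CC2)c(=O)[nH]c1=O`: 25100 nM.

Going by the values given here, in an ADME assay on MRC5 cells (Homo sapiens) for cytotoxicity, read by fluorescence and resazurin assay, with a stated time of 3 days (on this read-out lower numbers stand for stronger inhibition and higher numbers for weaker inhibition), compound 3 holds the only number among the three, the other two sitting at the limit (the limit of > 64000 nM in this assay, at which 2 of the 3 values shown sit). The steps of an at least 2.5-fold lower number from compound 1 to compound 3 (0.40 log units; beyond the scatter) and an at least 2.5-fold lower number from compound 2 to compound 3 (0.40 log units; beyond the scatter) both exchanged the aryl group on the ether oxygen and moved the reading off the limit. Compound 4 `Cc1cn(C2CCN(Cc3cccc(Oc4cccc(OC(F)(F)F)c4)c3)CC2)c(=O)[nH]c1=O` carries the change (3-(trifluoromethoxy)phenyl in place of 4-chlorophenyl on an oxygen on an aromatic ring), again an exchange of that aryl group. Since both measured exchanges of it away from the chlorophenyl gave only limits, the step of a 1.8-fold higher number from compound 3 to compound 4 (0.25 log units; within the scatter) is expected to run upward, toward weaker cytotoxicity. Compound 4 is therefore estimated at 45000 nM, within 15000 nM to 130000 nM.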

Compound 4, half-maximal inhibitory concentration: 5260 nM
The estimate for compound 4 lay 8.6-fold (0.93 log units) above the measured number, and the stated range ends above it.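

In this assay, going by these compounds alone, another exchange of the aryl group on this oxygen gave a 4.8-fold lower number from compound 3 to compound 4 (0.68 log units; beyond the scatter), so 4-chlorophenyl is not the only group here that gives a reading off the limit. The gaps to the other two aryl groups are an at least 12-fold lower number from compound 2 to compound 4 (1.08 log units; beyond the scatter) and an at least 12-fold lower number from compound 1 to compound 4 (1.08 log units; beyond the scatter), which makes this the strongest cytotoxicity of the four. Those two sizes are minimum sizes only: the limit of > 64000 nM in this assay, at which 2 of the 4 values shown sit.

On these data alone, it remains open whether a phenyl ring carrying an amine or a carboxylic acid at this place would keep the reading this low or return it to the limit. The same exchange on a core other than the shared one is also left open.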